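The compounds below may be only part of what the source reports. "The series", "measured", "known", "first", "only" and "open" are said of these compounds alone.

The series shares one core. Compound 1 `FC(F)(F)c1ccc(CSc2nc(N3CCCCC3)c3ccccc3n2)cc1` carries piperidin-1-yl, and in a functional assay on MGC-803 cells (Homo sapiens) for cytotoxicity, read by MTT assay, with a stated time of 72 h (a higher number here means a weaker inhibitor, a lower number a stronger inhibitor), compound 1 gives 18600 nM. Compound 2 `CCOc1ccccc1Nc1nc(SCc2ccc(C(F)(F)F)cc2)nc2ccccc12` carries (2-ethoxyphenyl)amino in its place. In this assay compound 2 returns only a limit of the assay, > 50000 nM, and no number (the limit of > 50000 nM in this assay, at which 1 of the 3 values shown sits). Compound 3 `O=[N+]([O-])c1ccc(Nc2nc(SCc3ccc(C(F)(F)F)cc3)nc3ccccc23)cc1` carries (4-nitrophenyl)amino and gives 8170 nM in this assay. The measured steps run an at least 2.6-fold higher number from compound 1 to compound 2 (0.42 log units; beyond the scatter), a 2.3-fold lower number from compound 1 to compound 3 (0.36 log units; beyond the scatter) and an at least 6.1-fold lower number from compound 2 to compound 3 (0.78 log units; beyond the scatter). On the numbers shown, compound 2 therefore stands at the weak end of the three, known only as a limit.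

Compound 4 `COc1ccc(Nc2nc(SCc3ccc(C(F)(F)F)cc3)nc3ccccc23)c(OC)c1` is not yet measured. It differs from compound 2 in one place: 2,4-dimethoxyphenyl in place of 2-ethoxyphenyl on a nitrogen on an aromatic ring. Among the compounds with values here, none of the measured steps exchanges one alkoxyphenyl for another; the single step away from compound 2, an at least 6.1-fold lower number from compound 2 to compound 3 (0.78 log units; beyond the scatter), leads to 4-nitrophenyl and says nothing about a second methoxy group. The steps from compound 1 show the arylamino replacements moving the number in both directions, but none of them points to a gain from this particular change. The expected step in this assay is a step that the limit leaves unreadable from compound 2 to compound 4, with a real chance that compound 4 again returns only a limit. The estimate for compound 4 is 55000 nM, expected to fall between 18000 nM and 150000 nM.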

Compound 4, half-maximal inhibitory concentration: > 50000 nM
Compound 4 gave a limit, no number; the forecaster's own chance of this, stated with the estimate: 55%; the middle value is on the limit's open side.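

In this assay compound 4 ends at a limit of the assay, as compound 2 did, so the step between them cannot be read, and a second alkoxyphenyl group on the nitrogen now sits at that same limit: the limit of > 50000 nM in this assay, at which 2 of the 4 values shown sit.

Compound 4 lies on the weak side of both measured neighbours, with an at least 6.1-fold higher number from compound 3 to compound 4 (0.78 log units; beyond the scatter) and an at least 2.6-fold higher number from compound 1 to compound 4 (0.42 log units; beyond the scatter). Among the arylamino groups on this aromatic carbon, the two alkoxy-bearing ones, in compound 2 and compound 4, both fall on the weak side of piperidin-1-yl in compound 1, a pattern that holds for these compounds only and that compound 3, with its (4-nitrophenyl)amino group, goes against.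

As far as these compounds go, whether 2-ethoxyphenyl and 2,4-dimethoxyphenyl differ at all in this assay stays open, since neither compound 2 nor compound 4 has a number. Also open, from the compounds shown here alone, is whether the result for compound 3 belongs to the nitro group alone or would carry over to a phenyl bearing a nitrile or a carboxylic acid.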